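The source may hold more compounds than are shown below. What is called first, only, known or untested is meant among the compounds shown, and "the series" means these compounds.

Compound 1 `COc1ccc2[nH]c(-c3nc(-c4ccccc4)no3)cc2c1`: in a functional assay on Jurkat cells (Homo sapiens) for antiproliferative activity, read by WST assay, with a stated time of 72 h (on this read-out higher numbers stand for weaker inhibition and lower numbers for stronger inhibition), compound 1 gives > 50000 nM, which is a limit of the assay and not a number.
Compound 2 `COc1ccc2[nH]c(-c3nc(-c4ccc(Cl)cc4)no3)cc2c1`: in this assay compound 2 gives > 50000 nM, again only a limit.

Compound 2 therefore stands at the limit of > 50000 nM in this assay, at which 2 of the 2 values shown sit, and no number is known for it. Among the compounds with values here, the single measured step, a step that the two limits leave unreadable from compound 1 to compound 2, joins two limits and yields no readable size. Compound 3 `COc1ccc(-c2noc(-c3cc4cc(OC)ccc4[nH]3)n2)cc1` differs from compound 2 by methoxy in place of chloro on an aromatic carbon. Within the data shown here, no measured step with a readable size bears on this change; the only one available is the unreadable step between the two measured compounds. Nothing seen here, then, points to a shift in this assay in either direction, nor to a gain large enough to bring a number within the range of the assay. Compound 3 is consequently expected to stay near the limit, the step that the limit leaves unreadable from compound 2 to compound 3 being estimated as none beyond the scatter. The estimate for compound 3 in this assay is 60000 nM, with a range from 15000 nM to 250000 nM.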

Compound 3, half-maximal inhibitory concentration: > 50000 nM
Compound 3 was reported as a limit; the forecaster's own chance of this, stated with the estimate: 80%; the middle value does not contradict the limit.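

Compound 3 gives a limit of the assay and not a number, as do compound 1 and compound 2, so no step among the three can be read: the limit of > 50000 nM in this assay, at which 3 of the 3 values shown sit.

The compounds shown leave open whether hydrogen, chloro and methoxy at this place differ at all in this assay.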